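Compound 3: a carbonyl substituent swap on compound 2

The compounds below may be only part of what the source reports. "The series", "measured", "known", "first", "only" and "open" are said of these compounds alone.

Two members of the series carry measurements. Compound 1 `COc1ccc(-c2cnc3nc(N)nc(N4CCN(c5cc(Cl)cc(Cl)c5)CC4)c3n2)cc1OC` gives 3400 nM in a functional assay on cells (T-cell, Homo sapiens) for inhibition (a higher number here means a weaker inhibitor, a lower number a stronger inhibitor), and compound 2 `COc1ccc(-c2cnc3nc(N)nc(N4CCN(C(=O)CCc5ccccc5)CC4)c3n2)cc1OC` gives 100 nM in this assay. Going by the values given here, the only measured step, a 34-fold lower number from compound 1 to compound 2 (1.53 log units; beyond the scatter), follows the change phenethylcarbonyl in place of 3,5-dichlorophenyl on an amine nitrogen in a ring. Among the compounds with values here, compound 2 thus holds the lower of the two numbers, with compound 1 as its only neighbour.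

Compound 3 `COc1ccc(-c2cnc3nc(N)nc(N4CCN(C(=O)COc5ccc(Cl)cc5)CC4)c3n2)cc1OC` keeps the carbonyl of compound 2 and alters the group attached through it: 4-chlorophenoxy in place of benzyl on a saturated chain carbon bound to a carbonyl carbon. Cut one bond further out, this reads phenethylcarbonyl to ((4-chlorophenoxy)methyl)carbonyl. The step of a 34-fold lower number from compound 1 to compound 2 (1.53 log units; beyond the scatter) concerns a carbonyl group against a directly attached aryl, not a change within the carbonyl substituent, so it bears on compound 3 only in that the carbonyl is retained. Within the data shown here, no measured step tests the group on the chain carbon. A step of a 1.5-fold higher number from compound 2 to compound 3 (0.18 log units; within the scatter) is expected, likely within the scatter. For compound 3 a value of 150 nM is estimated, in the range 40 nM to 600 nM.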

Compound 3, half-maximal inhibitory concentration: 0.5 nM
Compound 3: middle estimate off by 300-fold (2.48 log units), on the high side; measured number below the stated range.
By their numbers in this assay, from the lowest: compound 3; then compound 2; then compound 1.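

In this assay the group on the saturated chain carbon bound to a carbonyl carbon proves decisive: with the carbonyl held constant, 4-chlorophenoxy in place of benzyl gives a 200-fold lower number from compound 2 to compound 3 (2.30 log units; beyond the scatter), a larger step than a 34-fold lower number from compound 1 to compound 2 (1.53 log units; beyond the scatter), so the carbonyl alone does not set the level. Taken as a whole, ((4-chlorophenoxy)methyl)carbonyl in place of 3,5-dichlorophenyl on the amine nitrogen in a ring gives a 6800-fold lower number from compound 1 to compound 3 (3.83 log units; beyond the scatter), the widest span in the series so far. No available evidence bears on the origin of this gain.

Compound 3 differs from compound 2 in both the oxygen and the chlorine, so their shares of the step remain unseparated; an unsubstituted phenoxy or a 4-chlorobenzyl group would divide them. Also open, going by these compounds, is how a longer chain before the phenoxy oxygen would read in this assay.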